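The source may hold more compounds than are shown below. What is called first, only, known or untested is meant among the compounds shown, and "the series" means these compounds.

Notes on the series

Compound 1 `O=C(Nc1ccc(OC(F)(F)F)cc1)c1cc(F)ccc1O` is the reference for this set. In a functional assay on NALM-6 cells (Homo sapiens) for cytotoxicity, read by luminescence and CellTiter-Glo, with a stated time of 3 days (a lower number here means a stronger inhibitor, a higher number a weaker inhibitor), compound 1 gives 1210 nM. Going by the values given here, compound 2 `O=C(Nc1ccc(OC(F)(F)F)c(Cl)c1)c1cc(F)ccc1O` carries the one change (chloro in place of hydrogen on an aromatic carbon); in this assay compound 2 gives 1000 nM, and the step is a 1.2-fold lower number from compound 1 to compound 2 (0.08 log units; within the scatter).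

Compound 3 `O=C(Nc1cccc(C(F)(F)F)c1)c1cc(F)ccc1O` rests on a different core; how its core differs from that of compound 1 is not broken down here. In this assay compound 3 gives 1800 nM. The values of compound 3 and compound 1 lie within the usual scatter of each other, as do those of compound 3 and compound 2.

Compound 4 `O=C(Nc1ccc(Cl)c(C(F)(F)F)c1)c1cc(F)ccc1O` is not yet measured. It differs from compound 3 by chloro in place of hydrogen on an aromatic carbon. This is the same kind of change as that from compound 1 to compound 2, but the surroundings differ: in compound 4 the chloro sits ortho to a trifluoromethyl group and para to a large group, whereas in compound 2 it sits ortho to a trifluoromethoxy group and meta to a large group.

With one earlier example only, the expected step in this assay is a 1.2-fold lower number from compound 3 to compound 4 (0.08 log units; within the scatter), resting on the step of a 1.2-fold lower number from compound 1 to compound 2 (0.08 log units; within the scatter) and on compound 3 at 1800 nM. Compound 4 is thus estimated at 1500 nM, expected between 700 nM and 3200 nM.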

Compound 4, half-maximal inhibitory concentration: 970 nM
Estimate against measurement, compound 4: 1.5-fold (0.19 log units) above; measured number inside the range.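

In this assay the chloro in place of hydrogen gives a 1.9-fold lower number from compound 3 to compound 4 (0.27 log units; within the scatter), and this step can be set beside the earlier one: the same change on two cores in this assay, a 1.2-fold lower number (0.08 log units; within the scatter) from compound 1 to compound 2 and a 1.9-fold lower number (0.27 log units; within the scatter) from compound 3 to compound 4, 1.5-fold (0.19 log units) apart, within the scatter of two such steps. On these two cores, then, the change carries over with no difference in size that can be told from the scatter. This does not show that the chloro has a real effect on either core, since neither step stands beyond the scatter, and two examples say nothing about a further core or about the chloro on other ring carbons.

From the compounds shown here alone, it remains open whether a group other than chloro on this aromatic carbon, such as a methyl, a nitrile or an amine, would give a step beyond the scatter. Going by these compounds, it also remains open how the numbers would respond if the trifluoromethyl or trifluoromethoxy group gave way to a carboxylic acid or a longer chain.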